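Ethyl to isopropyl on the shared core

This account rests on a few compounds, and the source may have more. Where it says the series, first, only, none or still open, it means among the compounds named here.

Within the data shown here, compound 3 `CCc1ccc(C(=O)NN(C(=O)c2ccccc2Cl)C(C)(C)C)cc1` gives the lowest number of the three measured so far: in an assay on cells for agonist activity at ecdysone receptor (Bombyx mori), read by a luciferase reporter, with a stated time of 24 h (a lower number here means that less compound is needed, a higher number that more compound is needed for the effect), compound 3 gives 5.75 nM. Compound 2 `Cc1ccc(C(=O)NN(C(=O)c2ccccc2Cl)C(C)(C)C)cc1` gives 18.6 nM, and compound 1 `CC(C)(C)N(NC(=O)c1ccc(Cl)cc1)C(=O)c1ccccc1Cl` gives 115 nM; the steps of a 3.2-fold lower number from compound 2 to compound 3 (0.51 log units; beyond the scatter) and a 20-fold lower number from compound 1 to compound 3 (1.30 log units; beyond the scatter) set compound 3 apart beyond the scatter. Compound 4 `CC(C)c1ccc(C(=O)NN(C(=O)c2ccccc2Cl)C(C)(C)C)cc1` differs from compound 3 by methyl in place of hydrogen on a saturated chain carbon bound to an aromatic carbon and a saturated chain carbon. The step that bears on it most closely is a 3.2-fold lower number from compound 2 to compound 3 (0.51 log units; beyond the scatter), a modest lowering when a methyl was added on the saturated chain carbon bound to an aromatic carbon; a 6.2-fold lower number from compound 1 to compound 2 (0.79 log units; beyond the scatter) points the same way. A second added methyl is therefore expected to lower the number again, by less than the step before it. The expected step is a 1.8-fold lower number from compound 3 to compound 4 (0.25 log units; within the scatter). For compound 4 the estimated value is 3.2 nM, with a range from 1.2 nM to 9 nM.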

Compound 4, half-maximal effective concentration: 24.6 nM
Compound 4: middle estimate off by 7.7-fold (0.89 log units), on the low side; the measured number lies above the stated range.
By their numbers in this assay, from the lowest: compound 3; then compounds 2 and 4 (each within the scatter of the next); then compound 1.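

In this assay the lowering seen as the chain grew at this position does not continue to isopropyl: a methyl added on the saturated chain carbon reverses the direction (a 4.3-fold higher number from compound 3 to compound 4 (0.63 log units; beyond the scatter)). The isopropyl group does not separate from methyl (a 1.3-fold higher number from compound 2 to compound 4 (0.12 log units; within the scatter)), yet it keeps a lower number than chloro (a 4.7-fold lower number from compound 1 to compound 4 (0.67 log units; beyond the scatter)). No evidence at hand bears on why the number turns upward here.

On these data alone, whether the turn follows from branching on that carbon or holds for any group beyond ethyl stays open; a straight propyl chain or a tert-butyl group at this place would tell these apart.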